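The source may hold more compounds than are shown below. What is called first, only, known or untested is meant among the compounds shown, and "the series" means these compounds.

Three compounds share one core, a methoxy-substituted aniline carrying a methylpiperazine ring and a sulfonamide, and differ only in the aromatic group attached to the sulfonyl. Compound 1 `COc1ccc(NS(=O)(=O)c2cccc([N+](=O)[O-])c2)cc1N1CCN(C)CC1` carries a 3-nitrophenyl there; in an assay on HeLa cells for binding affinity to 5-hydroxytryptamine receptor 6 (Homo sapiens) (on this read-out higher numbers stand for weaker inhibition and lower numbers for stronger inhibition), compound 1 gives 79.4 nM. Compound 2 `COc1ccc(NS(=O)(=O)c2c(F)c(Br)cc(F)c2Br)cc1N1CCN(C)CC1` gives 3.16 nM, and compound 3 `COc1ccc(NS(=O)(=O)c2c(C)sc3ccc(Cl)cc23)cc1N1CCN(C)CC1` gives 1.26 nM. Compound 1 thus stands at the highest number of the three, and both gaps that separate it from compound 2 and from compound 3 lie beyond the scatter; the two more heavily substituted aromatic groups go with the lower numbers.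

For the measured compounds named here, compound 4 `COc1ccc(NS(=O)(=O)c2ccccc2)cc1N1CCN(C)CC1` removes the one substituent compound 1 has: hydrogen in place of nitro on an aromatic carbon, so that 3-nitrophenyl becomes plain phenyl. Going by the values given here, no measured pair shows exactly this change, so the size of the step is uncertain. Given that the less substituted aromatic group of compound 1 already sits at 79.4 nM, the bare phenyl is expected to sit somewhat higher still, with an expected step of a 2.5-fold higher number from compound 1 to compound 4 (0.40 log units; beyond the scatter), although a step of no real size beyond the scatter cannot be ruled out. For compound 4 the expected value in this assay is 200 nM, within a range from 60 nM to 700 nM.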

Compound 4, inhibition constant: 10 nM
Beside the measured number, compound 4's estimate is 20-fold (1.30 log units) above it; measured number below the stated range.
By their numbers in this assay, from the lowest: compound 3; then compound 2; then compound 4; then compound 1.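

In this assay, hydrogen in place of nitro on the aromatic carbon gives a 7.9-fold lower number from compound 1 to compound 4 (0.90 log units; beyond the scatter), so at this position the plain phenyl goes with stronger inhibition than the 3-nitrophenyl. For the compounds shown here, this is the first pair in the set that differs in one place, which lets a single substituent be read on its own; the earlier compounds differed in the whole aromatic group. No supporting data here bear on the reason for this step.

One pair cannot show how other groups on the same aromatic carbon, such as an amine, a methoxy group or a chlorine atom, would compare with hydrogen. It also leaves open whether removing a nitro group from a different aromatic group on the shared core would give a step of similar size.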